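From 3,5-dimethoxyphenyl to 3-chlorophenyl: working notes on growth inhibition

A few compounds are considered here, and "the series" means these few. Any claim that something is new, unique, unknown or untested is made for them only; others in the source may bear on it.

compound 1 `CC(C)=CCn1cnc2c(Nc3cccc(Cl)c3)nc(N[C@H]3CC[C@H](N)CC3)nc21` gives 13500 nM
compound 2 `CCCCn1cnc2c(Nc3cc(OC)cc(OC)c3)nc(N[C@H]3CC[C@H](N)CC3)nc21` gives 20100 nM

In a functional assay on HCC827 cells (Homo sapiens) for inhibition, read by fluorescence, with a stated time of 72 h (a higher number here means a weaker inhibitor of growth, a lower number a stronger inhibitor of growth), compound 2 gives 20100 nM and lies within the usual scatter of compound 1, so the two numbers do not separate. Compound 3 `CCCCn1cnc2c(Nc3cccc(Cl)c3)nc(N[C@H]3CC[C@H](N)CC3)nc21` is not yet measured. Within the data shown here, it has 3-chlorophenyl in place of 3,5-dimethoxyphenyl on a nitrogen on an aromatic ring, a change counted as 3-chlorophenyl in place of 3,5-dimethoxyphenyl on a nitrogen on an aromatic ring and the only one between compound 2 and compound 3.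

Among the measured compounds shown here, no measured pair isolates this change, so its size can only be judged indirectly. Compound 1 also carries 3-chlorophenyl on such a nitrogen and gives 13500 nM as its value, which gives no sign of a large shift. A small step toward a lower number is expected, most likely not beyond the scatter. In this assay the estimated move is a 1.5-fold lower number from compound 2 to compound 3 (0.19 log units; within the scatter) and it is expected to stay modest. Compound 3 is estimated at 13000 nM with 6000 nM to 28000 nM as the expected range.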

Compound 3, concentration for 50% growth inhibition: 7200 nM
The estimate for compound 3 lay 1.8-fold (0.26 log units) above the measured number; the measured number falls inside the stated range.
By their numbers in this assay, from the lowest: compounds 3, 1 and 2 (each within the scatter of the next, the first and the last beyond it).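

In this assay, the change of 3,5-dimethoxyphenyl to 3-chlorophenyl on a nitrogen on an aromatic ring now has a size of its own, a 2.8-fold lower number from compound 2 to compound 3 (0.45 log units; beyond the scatter), whereas compound 1 and compound 2 differ in more than one place and could not isolate it. The chain place behaves differently: with 3-chlorophenyl held fixed, propyl in place of 2-methylprop-1-en-1-yl on a saturated chain carbon bound to an aromatic nitrogen gives a 1.9-fold lower number from compound 1 to compound 3 (0.27 log units; within the scatter), so this pair does not separate, and of the two single changes only the aryl one clears the scatter. No data are at hand that bear on the origin of either step.

Still open, from the compounds shown here alone, is whether the aryl step comes from gaining the chlorine or from losing the two methoxy groups, a question that 3-methoxyphenyl or plain phenyl on the same nitrogen would address. Also open, going by these compounds, are whether the step keeps its size with 2-methylprop-1-en-1-yl in the chain place, and how a longer chain such as hexyl would read there.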